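Ethynyl for cyano on a tosyl-sulfonamide diamide scaffold

The source may report more compounds than this note shows. Statements on the series, on what has been measured and on what is new or still open speak of the compounds shown alone.

Compound 1, `Cc1ccc(S(=O)(=O)N[C@@H](CC(=O)NC(C)(C)C)C(=O)NCCNC(=O)c2cc(Cl)ccn2)cc1`: in an ADME assay on Karpas-1106P cells (Homo sapiens) for cytotoxicity (a lower number here means that less compound is needed, a higher number that more compound is needed for the effect), compound 1 gives > 11100 nM, a limit of the assay rather than a number.
Compound 2, `Cc1ccc(S(=O)(=O)N[C@@H](CC(=O)NC(C)(C)C)C(=O)NCCNC(=O)c2cccc(C#N)c2)cc1`: in this assay compound 2 gives > 11100 nM, also only a limit.

Compound 2 therefore stands at the limit of > 11100 nM in this assay, at which 2 of the 2 values shown sit. The step that the two limits leave unreadable from compound 1 to compound 2 is unreadable. Compound 3, `C#Cc1cccc(C(=O)NCCNC(=O)[C@H](CC(=O)NC(C)(C)C)NS(=O)(=O)c2ccc(C)cc2)c1`, differs from compound 2 by ethynyl in place of cyano on an aromatic carbon. Among the measured compounds shown here, no measured step bears on this change, so compound 3 is expected to sit near the same limit, with an estimated step that the limit leaves unreadable from compound 2 to compound 3. Compound 3 is estimated at 20000 nM, between 8000 nM and 60000 nM.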

Compound 3, half-maximal effective concentration: > 11100 nM
Compound 3: no number, only a limit (the forecaster's own chance of this, stated with the estimate: 85%); the middle value does not contradict the limit.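

Compound 1, compound 2 and compound 3 all stop at a limit of the assay rather than a number, so no step between them can be read: the limit of > 11100 nM in this assay, at which 3 of the 3 values shown sit.

Whether ethynyl and cyano differ in this assay stays open, as does the concentration any of these compounds would need for the effect.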